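The source may hold more compounds than are shown below. What is called first, only, known or untested is meant among the compounds shown, and "the series" means these compounds.

Working notes on the series. Among the compounds with values here, in an ADME assay (Rattus norvegicus, strain Wistar Han) for metabolic stability (a lower number here means that the compound disappears faster, a higher number that the compound lasts longer), compound 1 `CCn1c(-c2cnc(C)nc2)nc2c(N[C@H]3CCN(C(=O)C4CCC4)C3)ncnc21` gives 0.6 h, the second highest of the three numbers so far. Compound 2 `CCn1c(-c2cnc(C)nc2)nc2c(O[C@H]3CCN(C(=O)C4CCC4)C3)ncnc21` gives 0.3 h in this assay, which lies within the scatter of the number for compound 1. Within the data shown here, compound 3 `CCn1c(-c2ccc(C(F)(F)F)nc2)nc2c(O[C@H]3CCN(C(=O)[C@H]4C[C@@H](OC)C4)C3)ncnc21` gives 3.3 h in this assay, a number beyond the scatter relative to compound 1; no single-change step connects the two, so only the two numbers themselves can be set side by side. Compound 4 `CCn1c(-c2cnc(C)nc2)nc2c(N[C@H]3CCN(C(=O)C4CC4)C3)ncnc21` is still to be measured; it differs from compound 1 as cyclopropyl in place of cyclobutyl on a carbonyl carbon. Only a small step is expected here, none beyond the scatter in either direction. Compound 4 is therefore estimated at 0.7 h, with a range of 0.3 h to 1.6 h. The step expected is a 1.2-fold higher number from compound 1 to compound 4 (0.07 log units; within the scatter).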

Compound 4, half-life: 2.7 h
Beside the measured number, compound 4's estimate is 3.9-fold (0.59 log units) below it, and the stated range ends below it.
By their numbers in this assay, from the lowest: compounds 2 and 1 (each within the scatter of the next); then compounds 4 and 3 (each within the scatter of the next).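

In this assay, cyclopropyl in place of cyclobutyl on a carbonyl carbon gives a 4.5-fold higher number from compound 1 to compound 4 (0.65 log units; beyond the scatter). This single-change step shows that, in the setting of compound 1, the number responds to a change of the small carbon ring at this place alone. Nothing available accounts for the size of this step.

As far as these compounds go, whether the same change would carry over to the setting of compound 2 remains open. Also open, from the compounds shown here alone, is how cyclopentyl or an open chain such as isopropyl on the same carbonyl carbon would read.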